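The source may report more compounds than this note shows. Statements on the series, on what has been measured and on what is new or still open speak of the compounds shown alone.

Compound 1 `O=C(Nc1cccc(-n2cc(-c3ccncc3)c(-c3ccc(Cl)c(O)c3)n2)c1)Nc1cccc(C(F)(F)F)c1`: > 32500 nM
Compound 2 `O=C(Nc1cccc(-n2cc(-c3ccncc3)c(-c3ccc(Cl)c(O)c3)n2)c1)Nc1ccc(Cl)c(Cl)c1`: > 32500 nM

In a functional assay on A549 cells (Homo sapiens) for inhibition, read by sulforhodamine B assay, with a stated time of 48 h (on this read-out lower numbers stand for higher toxicity in this test and higher numbers for lower toxicity in this test), compound 1 gives > 32500 nM, which is a limit of the assay and not a number. Compound 2 likewise gives only a limit in this assay, > 32500 nM. The step that the two limits leave unreadable from compound 1 to compound 2 is therefore unreadable, as both values sit at the limit of > 32500 nM in this assay, at which 2 of the 2 values shown sit. Compound 3 `O=C(Nc1cccc(-n2cc(-c3ccncc3)c(-c3ccc(Cl)c(O)c3)n2)c1)Nc1cc(C(F)(F)F)cc(C(F)(F)F)c1` differs from compound 1 by trifluoromethyl in place of hydrogen on an aromatic carbon. No readable step in this assay bears on this change. Because compound 1 rests at the limit of > 32500 nM in this assay, at which 2 of the 2 values shown sit, compound 3 is expected to rest there too, a step that the limit leaves unreadable from compound 1 to compound 3, giving an estimate of 40000 nM within 15000 nM to 120000 nM.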

Compound 3, concentration lethal to 50% of the cells: 11400 nM
Compound 3: the middle estimate sits 3.5-fold (0.55 log units) above what was measured; the measured number lies below the stated range.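

In this assay, trifluoromethyl in place of hydrogen on an aromatic carbon, meta to a trifluoromethyl group, gives an at least 2.8-fold lower number from compound 1 to compound 3 (0.45 log units; beyond the scatter), so this position can move the read-out towards higher toxicity in this test. On these data alone, compound 1 gives > 32500 nM, which is a limit of the assay and not a number, so the true size of the step stays unknown. Compound 3 alone has a readable number, while the other two compounds remain at the limit: the limit of > 32500 nM in this assay, at which 2 of the 3 values shown sit.

As far as these compounds go, whether a nitrile, a methoxy group or an amine on that same carbon would shift the read-out in the same way stays open.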